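The source may report more compounds than this note shows. Statements on the series, on what has been measured and on what is new or still open speak of the compounds shown alone.

Three compounds share a core in which a phenoxyacetic acid bearing a chloro group is joined through an alkyne to a second aromatic ring, and they were tested in an assay on CHO cells for displacement of a labelled ligand from prostaglandin D2 receptor 2 (Homo sapiens), read by scintillation counting; a lower number here means a stronger inhibitor, a higher number a weaker inhibitor. Compound 1, `COc1ccccc1C#Cc1cc(Cl)ccc1OCC(=O)O`, carries a methoxy on that second ring, and in this assay compound 1 gives 190 nM. That is the highest of the three numbers, so compound 1 is the weakest inhibitor here. Compound 3, `CC(C)(C)N1C(=O)c2ccc(C#Cc3cc(Cl)ccc3OCC(=O)O)cc2S1(=O)=O`, gives 14 nM in this assay, a lower number than compound 1 by a margin well beyond the scatter. Compound 2, `CCCS(=O)(=O)c1cc(C#Cc2cc(Cl)ccc2OCC(=O)O)c(C)cc1NC(C)=O`, gives 1.3 nM, the lowest of the three and again beyond the scatter from compound 1.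

Compound 4, `O=C(O)COc1ccc(Cl)cc1C#Cc1ccccc1Cl`, has not yet been measured. It differs from compound 1 in one place: chloro in place of methoxy on an aromatic carbon. For the measured compounds named here, no measured pair in this set makes a comparable swap, so there is no step to lean on, and the larger groups that lower the numbers in compound 2 and compound 3 are not involved. A single small substituent exchange is expected to move the number little, so the step from compound 1 to compound 4 is expected to be about a 1.3-fold lower number from compound 1 to compound 4 (0.10 log units; within the scatter), within the scatter or only slightly toward a stronger inhibitor. For compound 4 the expected value in this assay is 150 nM, with a likely range from 50 nM to 450 nM.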

Compound 4, inhibition constant: 28 nM
For compound 4 the middle estimate is 5.4-fold (0.73 log units) above the measured one; the measured number lies below the stated range.
By their numbers in this assay, from the lowest: compound 2; then compounds 3 and 4 (each within the scatter of the next); then compound 1.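

Exchanging one small group for another at this position is not a neutral edit: chloro in place of methoxy, on an aromatic carbon ortho to a large group, gives a 6.8-fold lower number from compound 1 to compound 4 (0.83 log units; beyond the scatter) in this assay, a step beyond the usual scatter. For the compounds shown here, this is the first pair in the set that differs in one place, so it shows that the second ring's substituent alone can move the number clearly, without the larger groups carried by compound 2 and compound 3. The change removes a methoxy of 2 heavy atoms and 1 hydrogen-bond acceptor and brings in a chloro of 1 heavy atom and no hydrogen-bond acceptor, but no measurement here shows what lies behind the step.

The compounds shown leave open how a bare hydrogen, a fluoro, a methyl or a trifluoromethyl would compare with chloro at this same position. They also leave open whether the same exchange would give a step of similar size on a second ring that carries further groups, such as the propylsulfonyl of compound 2.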